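Anilide variation on the shared core: notes toward compound 3

The compounds below may be only part of what the source reports. "The series", "measured", "known", "first", "only" and "open" are said of these compounds alone.

The series shares one core and varies only the aryl group on the amide nitrogen. Compound 1 is `COc1ccc2c(=O)c(/C=C/C(=O)Nc3cccc(C)c3)coc2c1` and compound 2 is `COc1ccc2c(=O)c(/C=C/C(=O)Nc3cccc(Cl)c3)coc2c1`. In a functional assay on L02 cells (Homo sapiens) for inhibition, read by MTT assay, with a stated time of 48 h (a lower number here means a stronger inhibitor, a higher number a weaker inhibitor), compound 1 reports only a limit, > 200000 nM. Compound 2 likewise reports only a limit in this assay, > 200000 nM. For the measured compounds named here, the single measured step, a step that the two limits leave unreadable from compound 1 to compound 2, is therefore unreadable in size, since both ends sit at the limit (the limit of > 200000 nM in this assay, at which 2 of the 2 values shown sit). Compound 2 thus stands at the limit of this assay, with no numerical value to place it against compound 1.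

Compound 3 is `COc1ccc2c(=O)c(/C=C/C(=O)Nc3ccc(F)cc3)coc2c1`. It differs from compound 2 as 4-fluorophenyl in place of 3-chlorophenyl on an amide-type nitrogen. Going by the values given here, the only measured step bearing on this change, from compound 1 to compound 2, shows nothing readable, so no direction or size of step in this assay can be drawn from the series beyond an expectation that compound 3 behaves like its neighbours. Compound 3 is therefore expected to stay at or near the limit, with an expected step that the limit leaves unreadable from compound 2 to compound 3. The estimate for compound 3 in this assay is 250000 nM, within 100000 nM to 700000 nM.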

Compound 3, half-maximal inhibitory concentration: > 200000 nM
Compound 3: no number, only a limit; the forecaster's own chance of this, stated with the estimate: 80%; the middle value lies beyond the limit too.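

Compound 3 gives only a limit in this assay (> 200000 nM). For the compounds shown here, no step among compound 1, compound 2 and compound 3 can be read: the limit of > 200000 nM in this assay, at which 3 of the 3 values shown sit. The compounds shown leave open whether any aryl group on the amide nitrogen of the shared core gives a numerical value in this assay and how 3-methylphenyl, 3-chlorophenyl and 4-fluorophenyl compare.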